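Swapping the sulfonamide ring for a phenyl sulfone

The compounds below may be only part of what the source reports. "The series", "measured", "known", "first", "only" and "open" are said of these compounds alone.

Compound 2 `CC1CCN(S(=O)(=O)c2ccc(NC(=O)c3ccc([N+](=O)[O-])o3)cc2)CC1` gives 700 nM in an assay on CHO-K1 cells for activation of DNA damage-inducible transcript 3 protein (Homo sapiens), read by a luciferase reporter; a lower number here means that less compound is needed, a higher number that more compound is needed for the effect. That places it level with compound 3 `O=C(Nc1ccc(S(=O)(=O)N2CCC3(CCCCC3)CC2)cc1)c1ccc([N+](=O)[O-])o1`, which gives 700 nM, the two together holding the lowest of the three numbers, while compound 1 `O=C(Nc1ccc(S(=O)(=O)N2CCC(O)CC2)cc1)c1ccc([N+](=O)[O-])o1` gives 2000 nM; the step of a 2.9-fold lower number from compound 1 to compound 2 (0.46 log units; beyond the scatter) separates those two. Compound 4 `O=C(Nc1ccc(S(=O)(=O)c2ccccc2)cc1)c1ccc([N+](=O)[O-])o1` differs from compound 2 by phenyl in place of 4-methylpiperidin-1-yl on a sulfonyl sulfur. Among the compounds with values here, none of the measured steps bears directly on this change, since all three measured compounds keep a saturated nitrogen ring on the sulfonyl sulfur, and the only measured step, hydroxy to methyl, was modest. The expected step of a 1.4-fold higher number from compound 2 to compound 4 (0.15 log units; within the scatter) is therefore small, possibly not beyond the scatter, with more uncertainty than usual. Compound 4 is estimated at 1000 nM, within 300 nM to 4000 nM.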

Compound 4, concentration for half-maximal activity: 1100 nM
Compound 4: the middle estimate sits 1.1-fold (0.04 log units) below what was measured, and the stated range covers the measured number.
By their numbers in this assay, from the lowest: compounds 2, 3, 4 and 1 (each within the scatter of the next, the first and the last beyond it).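

In this assay, replacing 4-methylpiperidin-1-yl with phenyl on the sulfonyl sulfur gives a 1.6-fold higher number from compound 2 to compound 4 (0.20 log units; within the scatter), and replacing 4-hydroxypiperidin-1-yl with phenyl gives a 1.8-fold lower number from compound 1 to compound 4 (0.26 log units; within the scatter). Both steps stay within the scatter, so this place accepts an aromatic carbon ring as well as a saturated nitrogen ring, and compound 4 cannot be placed on either side of the gap between the hydroxy and methyl rings. Nothing available accounts for these numbers.

On these data alone, whether a carboxylic acid or a methoxy group on the phenyl ring would shift the number remains open, as does the effect of an open-chain amine on the sulfonyl sulfur.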